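This account rests on a few compounds, and the source may have more. Where it says the series, first, only, none or still open, it means among the compounds named here.

- Compound 1 `COc1ccc(SCc2ccc(/C=C/C(=O)Nc3ccccc3N)cc2)cc1OC`: 65.5%
- Compound 2 `Nc1ccccc1NC(=O)/C=C/c1ccc(CSc2cccc(F)c2)cc1`: 50.7%

Among the compounds with values here, in a functional assay on A549 cells (Homo sapiens) for inhibition, read by CCK-8 assay, with a stated time of 72 h, tested at 2 uM (on this read-out higher numbers stand for more inhibition of growth at the one concentration tested and lower numbers for less inhibition of growth), compound 1 holds the higher of the two numbers, at 65.5%, and its only neighbour is compound 2, at 50.7%. The next compound, compound 3 `CCc1ccc(SCc2ccc(/C=C/C(=O)Nc3ccccc3N)cc2)cc1`, keeps the core of compound 1 and changes only the aryl group on the sulfur: 4-ethylphenyl in place of 3,4-dimethoxyphenyl on a sulfur. Within the data shown here, one measured step bears on this, at the same place: a number 14.8 percentage points lower from compound 1 to compound 2 (beyond the scatter), a modest step beyond the scatter, with 3-fluorophenyl in place of 3,4-dimethoxyphenyl. Among the measured compounds shown here, no measured compound carries 4-ethylphenyl, so this single step is a rough guide only. A fall of similar or somewhat smaller size is therefore expected in this assay. Compound 3 is expected at 55%, with an estimated range from 40% to 69%. The estimated change is a number 10.5 percentage points lower from compound 1 to compound 3 (beyond the scatter).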

Compound 3, percent growth inhibition at one concentration: 60.7%
Compound 3: the middle estimate sits 5.7 percentage points below what was measured, within the range that was stated.
By their numbers in this assay, from the lowest: compounds 2, 3 and 1 (each within the scatter of the next, the first and the last beyond it).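

Moving to 4-ethylphenyl on the sulfur gives a number 4.8 percentage points lower from compound 1 to compound 3 (within the scatter) in this assay, so at this position 3,4-dimethoxyphenyl can give way to an aryl group with no hydrogen-bond acceptors without a change this read-out can resolve. Compound 3 is not separated from compound 2 either, with 4-ethylphenyl in place of 3-fluorophenyl giving a number 10 percentage points higher from compound 2 to compound 3 (within the scatter), and so the fall seen with 3-fluorophenyl does not clearly extend to this second replacement of 3,4-dimethoxyphenyl. No supporting data are available to explain these numbers.

As far as these compounds go, it remains open whether a longer chain in place of the ethyl group, or an amine or a carboxylic acid on the same ring, would keep the inhibition of growth at this level. Whether the small difference between the 4-ethylphenyl and 3,4-dimethoxyphenyl groups would hold at other concentrations also stays unsettled.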